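Carboxy in Place of Trifluoromethyl on a Weak Sulfonamide Series

A few compounds are considered here, and "the series" means these few. Any claim that something is new, unique, unknown or untested is made for them only; others in the source may bear on it.

Measured so far:
- compound 1, `COc1cc2nc(N3CCN(S(=O)(=O)c4ccc(Cl)s4)CC3)nc(N)c2cc1OC`, gives 25000 nM in a functional assay on PC-3 cells (Homo sapiens) for inhibition; on this read-out lower numbers stand for stronger inhibition and higher numbers for weaker inhibition
- compound 2, `COc1cc2nc(N3CCN(S(=O)(=O)c4ccc(C(F)(F)F)cc4)CC3)nc(N)c2cc1OC`, gives 27000 nM in this assay

For the measured compounds named here, compound 2 holds the higher of the two numbers, yet the only measured step, a 1.1-fold higher number from compound 1 to compound 2 (0.03 log units; within the scatter), lies within the usual scatter, so the two compounds cannot be told apart on this read-out; both inhibit only weakly.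

Compound 3, `COc1cc2nc(N3CCN(S(=O)(=O)c4ccc(C(=O)O)cc4)CC3)nc(N)c2cc1OC`, differs from compound 2 by carboxy in place of trifluoromethyl on an aromatic carbon. Going by the values given here, no measured step touches a carboxy group. Among the compounds with values here, the single step available exchanged the whole ring on the sulfonyl sulfur and left the number within the scatter, which suggests this part of the molecule is not where the number is decided. Compound 3 is therefore expected to stay in the same weak region, with an expected step of a 1.1-fold higher number from compound 2 to compound 3 (0.05 log units; within the scatter). The estimate for compound 3 in this assay is 30000 nM, ranging from 8000 nM to 100000 nM.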

Compound 3, half-maximal inhibitory concentration: 53000 nM
Compound 3: middle estimate off by 1.8-fold (0.25 log units), on the low side; low and high end bracket the measured number.
By their numbers in this assay, from the lowest: compounds 1, 2 and 3 (each within the scatter of the next, the first and the last beyond it).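

Putting carboxy on this ring in place of trifluoromethyl, a swap that brings in a hydrogen-bond donor, gives a 2.0-fold higher number from compound 2 to compound 3 (0.29 log units; within the scatter) and so does not separate the two compounds in this assay. For the compounds shown here, measured against 5-chlorothiophen-2-yl on the sulfonyl sulfur, however, 4-carboxyphenyl gives a 2.1-fold higher number from compound 1 to compound 3 (0.33 log units; beyond the scatter), the first step here to pass beyond the scatter, though a modest one towards weaker inhibition. Nothing at hand explains this small shift.

Going by these compounds, all three compounds remain weak inhibitors, and it stays open whether another group at this spot, such as an amine, a primary amide or a methyl ester, would give a clearly lower number. Also open, on these data alone, is whether changes to the shared core, away from the group on the sulfonyl sulfur, would move the number further.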